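Fluoro for methyl beside the methoxy group

The compounds below may be only part of what the source reports. "The series", "measured", "known", "first", "only" and "open" are said of these compounds alone.

Compounds measured so far in a functional assay on MCF7 cells (Homo sapiens) for inhibition; a higher number here means a weaker inhibitor, a lower number a stronger inhibitor:
compound 1 `COc1ccc(-c2nc3ccc(F)cc3o2)cc1` — compound 1 gives 41000 nM
compound 2 `COc1ccc(-c2nc3cc(F)ccc3s2)cc1` — compound 2 gives 490 nM
compound 3 `COc1ccc(-c2nc3cc(F)ccc3s2)cc1C` — compound 3 gives 48 nM

Compound 3 stands lowest of the three in this assay; compound 2 is nearest, and compound 1 lies far higher. Compound 4 `COc1ccc(-c2nc3cc(F)ccc3s2)cc1F` differs from compound 3 by fluoro in place of methyl on an aromatic carbon. Among the compounds with values here, the one step that bears on this position is a 10-fold lower number from compound 2 to compound 3 (1.01 log units; beyond the scatter), which shows the methyl at this place carrying a large gain. Within the data shown here, no measured step shows fluoro at this place. He therefore expects compound 4 to lose part of that gain, with a step of a 3.1-fold higher number from compound 3 to compound 4 (0.49 log units; beyond the scatter), rising toward compound 2 but not reaching it. His estimate for compound 4 is 150 nM, within 40 nM to 600 nM.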

Compound 4, half-maximal inhibitory concentration: 870 nM
The estimate for compound 4 lay 5.8-fold (0.76 log units) below the measured number, and the stated range ends below it.
By their numbers in this assay, from the lowest: compound 3; then compounds 2 and 4 (each within the scatter of the next); then compound 1.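

In this assay the change to fluoro brings an 18-fold higher number from compound 3 to compound 4 (1.26 log units; beyond the scatter) and so removes the gain that methyl gave at this place. Fluoro in place of hydrogen gives a 1.8-fold higher number from compound 2 to compound 4 (0.25 log units; within the scatter) and thus cannot be told apart from hydrogen here. Of the three groups seen at this carbon, only methyl carries a gain, so the gain does not come with any replacement of hydrogen. Nothing available accounts for the gap between methyl and fluoro. As far as these compounds go, whether an ethyl group or a chlorine atom at this place would keep the gain remains open.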